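Chloro to fluoro on the aryl ring: compound 4

The source may hold more compounds than are shown below. What is called first, only, known or untested is meant among the compounds shown, and "the series" means these compounds.

Measured compounds, with numbers from a functional assay on CHO cells for antagonist activity at corticotropin-releasing factor receptor 1 (Homo sapiens), read by cAMP accumulation; on this read-out lower numbers stand for stronger inhibition and higher numbers for weaker inhibition:
compound 1 `COCc1nc2c(NC(C3CC3)C3CC3)nc(C)nc2n1-c1ccc(OC)cc1`: 157 nM
compound 2 `Cc1nc(NC(C2CC2)C2CC2)c2nc(C)n(-c3ccc(OC(F)F)cc3)c2n1`: 5 nM
compound 3 `Cc1nc(NC(C2CC2)C2CC2)c2nc(C)n(-c3ccc(OC(F)F)cc3Cl)c2n1`: 0.373 nM

Compound 3 gives the lowest of the three numbers in this assay. Going by the values given here, the nearest is compound 2, separated from it by the single change chloro in place of hydrogen on an aromatic carbon, a step of a 13-fold lower number from compound 2 to compound 3 (1.13 log units; beyond the scatter). Compound 1 lies far higher still.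

Compound 4 `Cc1nc(NC(C2CC2)C2CC2)c2nc(C)n(-c3ccc(OC(F)F)cc3F)c2n1` differs from compound 3 by fluoro in place of chloro on an aromatic carbon. Among the compounds with values here, the only measured step that bears on this position is a 13-fold lower number from compound 2 to compound 3 (1.13 log units; beyond the scatter), where chloro entered. Replacing that chloro with fluoro is expected to lose part of that change, so for compound 4 a step of a 2.7-fold higher number from compound 3 to compound 4 (0.43 log units; beyond the scatter) in this assay is expected. Compound 4 is estimated at 1 nM, with a range of 0.3 nM to 3.5 nM.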

Compound 4, inhibition constant: 7 nM
For compound 4 the middle estimate is 7.0-fold (0.85 log units) below the measured one; measured number above the stated range.
By their numbers in this assay, from the lowest: compound 3; then compounds 2 and 4 (each within the scatter of the next); then compound 1.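

In this assay the gain at this position belongs to chloro and not to halogen in general: swapping it for fluoro gives a 19-fold higher number from compound 3 to compound 4 (1.27 log units; beyond the scatter) and so undoes the gain. Fluoro in place of hydrogen gives a 1.4-fold higher number from compound 2 to compound 4 (0.15 log units; within the scatter) and so brings no measurable gain over compound 2. No measured data explain why chloro and fluoro part here.

Open, going by these compounds, is whether bromo, methyl or trifluoromethyl at this place would track chloro or fluoro. Also open, on these data alone, is whether the chloro gain holds with the methoxymethyl group of compound 1 on the shared core.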